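The compounds below may be only part of what the source reports. "The series", "measured", "known", "first", "only" and "open" are said of these compounds alone.

Within the data shown here, compound 1 `CCOc1ccc(C(=O)/C=C/c2ccc(C(=O)Nc3cccc(-c4cc(C(=O)OC)no4)c3)cc2)cc1` is the better-tolerated member of the two compounds measured so far. In an ADME assay on Vero cells (Chlorocebus sabaeus) for cytotoxicity, read by MTT assay, with a stated time of 72 h (a lower number here means that less compound is tolerated, a higher number that more compound is tolerated), compound 1 gives > 40 ug/mL, which is a limit of the assay and not a number; compound 1 stands at the limit of > 40 ug/mL in this assay, at which 1 of the 2 values shown sits. Compound 2 `O=C(O)c1ccc(/C=C/C(=O)c2ccc(Cl)cc2)cc1` is the other measured member. In this assay compound 2 gives < 10 ug/mL, again a limit and not a number, so compound 2 stands at the limit of < 10 ug/mL in this assay, at which 1 of the 2 values shown sits. Among the measured compounds shown here, the two values show only that compound 1 is tolerated where compound 2 is not, and no step between measured compounds is available from them. Compound 3 `COC(=O)c1cc(-c2cccc(NC(=O)c3ccc(/C=C/C(=O)c4ccc(OC)c(OC)c4)cc3)c2)on1` has not yet been measured in this assay. It differs from compound 1 in one place: 3,4-dimethoxyphenyl in place of 4-ethoxyphenyl on a carbonyl carbon. For the measured compounds named here, with no measured step to rest on, the expected change is none beyond the scatter, so compound 3 is expected to remain at the tolerated end of this assay. Compound 3 is estimated at 45 ug/mL in this assay, within 22 ug/mL to 90 ug/mL. The step this estimate means, a step that the limit leaves unreadable from compound 1 to compound 3, is expected to lie within the scatter.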

Compound 3, half-maximal cytotoxic concentration: > 50 ug/mL
Compound 3 gave a limit, no number; the forecaster's own chance of this, stated with the estimate: 70%; middle value at least 1.1-fold (0.04 log units) away from the limit.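

In this assay compound 3 gives > 50 ug/mL, a limit and not a number. Compound 1 also stands at a limit, so no step can be read between compound 1 and compound 3. Open, on these data alone, is whether 3,4-dimethoxyphenyl in place of 4-ethoxyphenyl changes tolerance at all.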